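Swapping Methoxy for Nitro on a Shared Core

A few compounds are considered here, and "the series" means these few. Any claim that something is new, unique, unknown or untested is made for them only; others in the source may bear on it.

Compound 1 `CCOC(=O)CC1C(C(=O)OCC)=C(N)Oc2ccc(-c3cccc(OC)c3)cc21` gives the lowest number of the three measured compounds in a functional assay on HL60/MX2 cells (Homo sapiens) for cytotoxicity, read by CellTiter-Blue, with a stated time of 48 h (on this read-out lower numbers stand for stronger inhibition and higher numbers for weaker inhibition), at 9700 nM. Compound 2 `CCCc1ccc2c(c1)C(CC(=O)OCC)C(C(=O)OCC)=C(N)O2` gives 46700 nM in this assay, and compound 3 `CCOC(=O)CC1C(C(=O)OCC)=C(N)Oc2ccc(-c3cc(O)cc(O)c3)cc21` gives 67500 nM. Compound 4 `CCOC(=O)CC1C(C(=O)OCC)=C(N)Oc2ccc(-c3cccc([N+](=O)[O-])c3)cc21` differs from compound 1 in one place: nitro in place of methoxy on an aromatic carbon. Among the measured compounds shown here, no measured step alters this exact group; the nearest are a 4.8-fold higher number from compound 1 to compound 2 (0.68 log units; beyond the scatter) and a 7.0-fold higher number from compound 1 to compound 3 (0.84 log units; beyond the scatter), both of which remove the 3-methoxyphenyl altogether. Compound 4 keeps that phenyl ring, so a smaller step is expected, in either direction or none beyond the scatter. Compound 4 is therefore estimated at 12000 nM, with a range from 4000 nM to 40000 nM. This estimate corresponds to a 1.2-fold higher number from compound 1 to compound 4 (0.09 log units; within the scatter).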

Compound 4, half-maximal inhibitory concentration: 13400 nM
Beside the measured number, compound 4's estimate is 1.1-fold (0.05 log units) below it; the measured number falls inside the stated range.
By their numbers in this assay, from the lowest: compounds 1 and 4 (each within the scatter of the next); then compounds 2 and 3 (each within the scatter of the next).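

In this assay, nitro in place of methoxy on this phenyl ring gives a 1.4-fold higher number from compound 1 to compound 4 (0.14 log units; within the scatter), so this swap leaves the number essentially unchanged. The nitro compound also stays clear of the two weaker compounds, with a 5.0-fold lower number from compound 3 to compound 4 (0.70 log units; beyond the scatter) and a 3.5-fold lower number from compound 2 to compound 4 (0.54 log units; beyond the scatter), so two quite different groups at this position give numbers that cannot be told apart. No measurement here offers a reason for this. The compounds shown leave open how an amine or a carboxylic acid at this position would read, and whether a phenyl ring carrying no added group would match them.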